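Sulfoxide to sulfone on two related triazole cores

This account rests on a few compounds, and the source may have more. Where it says the series, first, only, none or still open, it means among the compounds named here.

Compound 1 `Cc1ccc(-c2nnc([S+](C)[O-])n2C)cc1`: > 200 mg/kg
Compound 2 `Cc1ccc(-c2nnc(S(C)(=O)=O)n2C)cc1`: > 200 mg/kg
Compound 3 `Cn1nc([S+](C)[O-])nc1-c1ccccc1`: > 200 mg/kg

All three measured compounds were tested in a functional assay on the whole organism for antagonist activity, with Mus musculus as the target; a lower number here means that less compound is needed, a higher number that more compound is needed for the effect. In this assay compound 1 gives only a limit, > 200 mg/kg. Compound 2 likewise gives only a limit, > 200 mg/kg. Compound 3 too gives only a limit, > 200 mg/kg. The change from compound 1 to compound 2 is a group of 4 heavy atoms (1 carbon, 2 oxygen, 1 sulfur; no ring) in place of a group of 3 heavy atoms (1 carbon, 1 oxygen, 1 sulfur; no ring), on an aromatic carbon, and the step it made is a step that the two limits leave unreadable from compound 1 to compound 2; with the limit of > 200 mg/kg in this assay, at which 3 of the 3 values shown sit, no size can be read.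

Compound 4 `Cn1nc(S(C)(=O)=O)nc1-c1ccccc1` has not yet been measured. It arises from compound 3 by a group of 4 heavy atoms (1 carbon, 2 oxygen, 1 sulfur; no ring) in place of a group of 3 heavy atoms (1 carbon, 1 oxygen, 1 sulfur; no ring), on an aromatic carbon, the same kind of change as from compound 1 to compound 2, though the surroundings on the core differ, as the structures of compound 1 and compound 3 show. How the core of compound 3 differs from the core of compound 1 is not broken down here.

Given that compound 3 sits at the limit > 200 mg/kg, the step from compound 3 to compound 4 is expected to be a step that the limit leaves unreadable from compound 3 to compound 4. Compound 4 is therefore estimated at 400 mg/kg, most likely again reported only as a limit.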

Compound 4, dose for half-maximal effect: > 200 mg/kg
Compound 4: no number, only a limit; the forecaster's own chance of this, stated with the estimate: 85%; the middle value does not contradict the limit.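

In this assay compound 4 gives > 200 mg/kg and this is a limit, not a number. No size can therefore be read for the change from compound 3 to compound 4: the limit of > 200 mg/kg in this assay, at which 4 of the 4 values shown sit. The compounds shown leave open how much of any of them is needed for the effect in this assay and whether methylsulfonyl makes any difference on either core.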